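The source may hold more compounds than are shown below. What is called first, only, known or untested is meant among the compounds shown, and "the series" means these compounds.

In a functional assay on MT4 cells (Homo sapiens) for cytotoxicity (on this read-out lower numbers stand for higher toxicity in this test and higher numbers for lower toxicity in this test), compound 1 `CC(C)Sc1nc(Cc2c(F)cccc2F)cc(=O)[nH]1` gives > 200000 nM, which is a limit and not a number. Compound 2 `O=c1cc(Cc2c(F)cccc2F)nc(SC2CCCC2)[nH]1` gives > 200000 nM, again only a limit, so its standing on this scale has no exact figure. Among the compounds with values here, the one measured step that bears on it is a step that the two limits leave unreadable from compound 1 to compound 2, and it offers no size to carry forward. The picture so far is thin: the limit of > 200000 nM in this assay, at which 2 of the 3 values shown sit. Within the data shown here, compound 3 `CCC(c1ccccc1)c1cc(O)nc(SC2CCCCC2)n1` is the only compound with a readable number, 51000 nM, and it carries a chain on the saturated carbon, though it also differs from compound 2 elsewhere.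

Compound 4 `CC(c1cc(=O)[nH]c(SC2CCCC2)n1)c1c(F)cccc1F` is compound 2 with one small change: methyl in place of hydrogen on a saturated chain carbon bound to two aromatic carbons. That adds a single methyl on the saturated chain carbon bound to two aromatic carbons. Among the measured compounds shown here, with compound 3 at 51000 nM as the only guide, a modest move towards the lower, more toxic side of the scale is expected. For compound 4, another result that is only a limit would be no surprise. The expected change is an at least 1.3-fold lower number from compound 2 to compound 4 (0.12 log units; that floor lies within the scatter), and this estimate remains loose. Compound 4 is estimated at 150000 nM, with an expected range from 50000 nM to 300000 nM.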

Compound 4, half-maximal cytotoxic concentration: > 200000 nM
Compound 4 was reported as a limit (the forecaster's own chance of this, stated with the estimate: 55%); middle value at least 1.3-fold (0.12 log units) from the limit.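

Compound 2 and compound 4 are both reported only as limits in this assay, so the step from one to the other cannot be read. The compounds shown leave open whether adding the methyl changes the cytotoxic concentration at all, and most of the values stop at the same limit: the limit of > 200000 nM in this assay, at which 3 of the 4 values shown sit.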